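Bromo in place of thiophene at the aromatic carbon

The source may report more compounds than this note shows. Statements on the series, on what has been measured and on what is new or still open speak of the compounds shown alone.

Compound 3 `COc1cc(NC(C)CCCNC(=O)C2CCC3(CC2)OOC2(OO3)C3CC4CC(C3)CC2C4)c2ncccc2c1-c1ccsc1` stands highest of the three numbers in an ADME assay on microsomes from liver (Rattus norvegicus) for metabolic stability, read by HPLC, using NADPH, tested at 1 mM; on this read-out higher numbers stand for fast clearance and lower numbers for slow clearance; compound 1 `COc1cc(NC(C)CCCNC(=O)C2CCC3(CC2)OOC2(OO3)C3CC4CC(C3)CC2C4)c2ncccc2c1-c1ccccc1` with 33 uL/min sits nearest, and compound 2 `COc1cc(NC(C)CCCNC(=O)C2CCC3(CC2)OOC2(OO3)C3CC4CC(C3)CC2C4)c2ncccc2c1-c1ccc(C(F)(F)F)cc1` with 13.9 uL/min sits furthest. In this assay compound 3 gives 37.4 uL/min. The step of a 1.1-fold higher number from compound 1 to compound 3 (0.05 log units; within the scatter) and the step of a 2.7-fold higher number from compound 2 to compound 3 (0.43 log units; beyond the scatter) frame where it sits.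

Compound 4 `COc1cc(NC(C)CCCNC(=O)C2CCC3(CC2)OOC2(OO3)C3CC4CC(C3)CC2C4)c2ncccc2c1Br` differs from compound 3 by bromo in place of thiophen-3-yl on an aromatic carbon. Of the measured steps, a 2.4-fold lower number from compound 1 to compound 2 (0.38 log units; beyond the scatter) concerns a trifluoromethyl added to the phenyl, while a 1.1-fold higher number from compound 1 to compound 3 (0.05 log units; within the scatter) exchanges phenyl for thiophen-3-yl; none replaces an aromatic ring with a single bromine at this aromatic carbon, so they bear on the change only loosely. The three numbers in hand also spread modestly. Compound 4 is therefore expected to show a 1.2-fold lower number from compound 3 to compound 4 (0.10 log units; within the scatter), a step that may well fall within the scatter. The estimate for compound 4 in this assay is 30 uL/min, with a range from 12 uL/min to 65 uL/min.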

Compound 4, intrinsic clearance in a liver preparation (reported as CLH), per the amount of preparation that the assay uses: 99 uL/min
The estimate for compound 4 lay 3.3-fold (0.52 log units) below the measured number, outside the stated range (above it).
By their numbers in this assay, from the lowest: compound 2; then compounds 1 and 3 (each within the scatter of the next); then compound 4.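

Replacing an aromatic ring with bromo at this aromatic carbon raises the number in this assay whichever ring leaves (with thiophen-3-yl a 2.6-fold higher number from compound 3 to compound 4 (0.42 log units; beyond the scatter); with phenyl a 3.0-fold higher number from compound 1 to compound 4 (0.48 log units; beyond the scatter); with 4-(trifluoromethyl)phenyl a 7.1-fold higher number from compound 2 to compound 4 (0.85 log units; beyond the scatter)). The earlier compounds had shown only ring-for-ring exchanges here, with phenyl and thiophen-3-yl lying within the scatter of each other, whereas this single bromine gives the highest number of the four and lies beyond the scatter from all three. Nothing available accounts for this rise.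

As far as these compounds go, whether the higher number belongs to bromo itself or to the absence of a ring at this carbon stays open. A chloro group, a methyl group or an amine at the same carbon would separate these two readings.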